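The source may report more compounds than this note shows. Statements on the series, on what has been measured and on what is new or still open speak of the compounds shown alone.

Compound 1 (`COc1cc(C(=O)n2ccc3ccccc32)cc(OC)c1OC`): > 10000 nM
Compound 2 (`COc1cc(C(=O)c2cccc3c2ccn3C)cc(OC)c1OC`): 28.8 nM
Compound 3 (`CCn1ccc2cc(C(=O)c3cc(OC)c(OC)c(OC)c3)ccc21`): 38 nM

All three values come from a functional assay on NCI-H460 cells (Homo sapiens) for inhibition, with a stated time of 72 h; on this read-out higher numbers stand for weaker inhibition and lower numbers for stronger inhibition. Compound 1 gives > 10000 nM, which is a limit of the assay and not a number. Compound 2 (28.8 nM) and compound 3 (38 nM) lie within the usual scatter of each other, so compound 3 stands level with compound 2 on these numbers.

The next compound to be tested is compound 4 (`COc1cc(C(=O)c2ccc3c(ccn3CC(=O)O)c2)cc(OC)c1OC`). It differs from compound 3 by one change: carboxy in place of methyl on a saturated chain carbon bound to an aromatic nitrogen. In words, this is carboxy in place of methyl on a saturated chain carbon bound to an aromatic nitrogen, or ethyl to carboxymethyl when the cut is made one bond further out.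

Going by the values given here, no measured pair in this set shows what such a change does in this assay, so the expectation rests on the structural change alone and is uncertain. A clear rise in the number, meaning weaker inhibition, is expected rather than a result within the scatter. The expected size of this move is a 53-fold higher number from compound 3 to compound 4 (1.72 log units; beyond the scatter), and it could be much smaller or larger. For compound 4 the estimated value is 2000 nM, with an expected range from 200 nM to 10000 nM.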

Compound 4, half-maximal inhibitory concentration: 530 nM
The estimate for compound 4 lay 3.8-fold (0.58 log units) above the measured number, within the range that was stated.
By their numbers in this assay, from the lowest: compounds 2 and 3 (each within the scatter of the next); then compound 4. At a limit, above all of these: compound 1.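

In this assay, going by these compounds alone, the swap of methyl for carboxy on a saturated chain carbon bound to an aromatic nitrogen gives a 14-fold higher number from compound 3 to compound 4 (1.14 log units; beyond the scatter), the first step in this set to show what a change at this place can do: the group carried here matters, and the move is well beyond ordinary repeat-to-repeat variation. The loss is only partial, since compound 4 still gives 530 nM, a real number and not a limit of the assay, so this place tolerates the carboxy group to a measurable degree. What lies behind the step remains unexplained, as nothing measured here speaks to its cause.

From the compounds shown here alone, it remains open whether an ester or an amide made from the same carboxymethyl chain, an amine in place of the carboxy, or a longer chain would give a number closer to that of compound 3 or closer to that of compound 4. One step on one core also cannot tell whether the same change would have a similar effect on the core of compound 2.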